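Benzyl to methylsulfanyl on the selenoimidate carbon

This account rests on a few compounds, and the source may have more. Where it says the series, first, only, none or still open, it means among the compounds named here.

Measured compounds:
compound 1 `C[Se]/C(=N\C(=O)c1cccs1)NC(=O)c1cccs1` — 0.34 nM
compound 2 `O=C(/N=C(/NC(=O)c1cccs1)[Se]Cc1ccccc1)c1cccs1` — 55100 nM

Both were read in a functional assay on HT-29 cells (Homo sapiens) for cytotoxicity, read by MTT assay, with a stated time of 72 h; on this read-out lower numbers stand for stronger inhibition of growth and higher numbers for weaker inhibition of growth. Compound 2 holds the highest of the two numbers; its nearest neighbour is compound 1, and the step of a 160000-fold higher number from compound 1 to compound 2 (5.21 log units; beyond the scatter) separates them, the change being a phenyl in place of a hydrogen on the saturated chain carbon bound to selenium.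

Compound 3 `CS/C(=N\C(=O)c1cccs1)NC(=O)c1cccs1` is not yet measured. Against compound 2 it shows (a group of 2 heavy atoms (1 carbon, 1 sulfur; no ring) in place of a group of 8 heavy atoms (7 carbon, 1 selenium; one six-membered aromatic ring of carbon only), on a carbon with a double bond to nitrogen). Among the compounds with values here, the one step that bears on this is a 160000-fold higher number from compound 1 to compound 2 (5.21 log units; beyond the scatter): removing the phenyl from the chain carbon undoes that large change, while the exchange of selenium for sulfur is not covered by any measured pair. A large step downward is therefore expected, roughly reversing the measured one, with wide uncertainty for the selenium-to-sulfur part. For compound 3 the estimated step is a 5500-fold lower number from compound 2 to compound 3 (3.74 log units; beyond the scatter). Compound 3 is expected to give 10 nM, within 0.5 nM to 300 nM.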

Compound 3, concentration for 50% growth inhibition: 77900 nM
For compound 3 the middle estimate is 7800-fold (3.89 log units) below the measured one, outside the stated range (above it).
By their numbers in this assay, from the lowest: compound 1; then compounds 2 and 3 (each within the scatter of the next).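

With the methyl group kept, sulfur in place of selenium on the carbon with a double bond to nitrogen gives in this assay a step of a 230000-fold higher number from compound 1 to compound 3 (5.36 log units; beyond the scatter) and is large, so the low number of compound 1 is lost through this atom exchange alone, without any added phenyl. The exchange of the group of 8 heavy atoms for methylsulfanyl gives a 1.4-fold higher number from compound 2 to compound 3 (0.15 log units; within the scatter) and leaves the two compounds within the scatter of each other. Of the three compounds, only compound 1, with methyl on selenium, stands apart.

No outside data bear on the reason for this selenium-to-sulfur step. Open, as far as these compounds go, is how far the low number tolerates change on selenium, as with an ethyl group or a longer chain in place of the methyl.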